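The compounds below may be only part of what the source reports. "The series", "measured", "known", "first", "only" and "open" are said of these compounds alone.

Compound 1, `O=C(Nc1ccc(C(F)(F)F)cc1)c1cccc(Nc2ncc(F)c(Nc3ccc(F)cc3)n2)c1`, with the trifluoromethylphenyl amide, gives only a limit in a functional assay on DU-145 cells (Homo sapiens) for antiproliferative activity, read by sulforhodamine B assay, with a stated time of 3 days (a lower number here means a stronger inhibitor of growth, a higher number a weaker inhibitor of growth), > 10000 nM. For the measured compounds named here, compound 2, `O=C(Nc1cccc(Nc2ncc(F)c(Nc3ccc(F)cc3)n2)c1)c1cnccn1`, bearing the pyrazinyl amide, is the one member of the pair with a measured number: in this assay compound 2 gives 26400 nM, while the other value shown is the limit of > 10000 nM in this assay, at which 1 of the 2 values shown sits. Compound 3, `CN1CCC(C(=O)Nc2cccc(Nc3ncc(F)c(Nc4ccc(F)cc4)n3)c2)CC1`, differs from compound 2 by 1-methylpiperidin-4-yl in place of pyrazin-2-yl on a carbonyl carbon. Going by the values given here, no measured step of this kind is available, so the step from compound 2 to compound 3 is expected to stay within the usual scatter, a 1.2-fold lower number from compound 2 to compound 3 (0.08 log units; within the scatter). Compound 3 is therefore estimated at 22000 nM, between 6000 nM and 70000 nM.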

Compound 3, concentration for 50% growth inhibition: 1150 nM
Estimate against measurement, compound 3: 19-fold (1.28 log units) above, outside the stated range (below it).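

In this assay, the group on the carbonyl carbon clearly matters: 1-methylpiperidin-4-yl in place of pyrazin-2-yl gives a 23-fold lower number from compound 2 to compound 3 (1.36 log units; beyond the scatter). For the compounds shown here, this is the first step between two measured numbers at this position, and it shows that growth inhibition responds to replacing an aromatic ring with a non-aromatic one carrying an amine nitrogen. Nothing shown accounts for the size of this step.

The compounds shown leave open whether the ring nitrogen or the non-aromatic ring drives the step. A cyclohexyl group or an unmethylated piperidin-4-yl in the same place would separate the two.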